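Difluorophenyl in place of methoxyphenyl on the enone carbonyl

The source may hold more compounds than are shown below. What is called first, only, known or untested is meant among the compounds shown, and "the series" means these compounds.

Two chalcone-type compounds sharing one core have been measured in a functional assay on RPMI-8226 cells (Homo sapiens) for inhibition, read by sulforhodamine B assay, with a stated time of 48 h; on this read-out lower numbers stand for stronger inhibition of growth and higher numbers for weaker inhibition of growth. Compound 1 `COc1cc(-c2cc(/C=C/C(=O)c3ccc(Cl)c(Cl)c3)[nH]n2)cc(OC)c1OC` gives 6730 nM, and compound 2 `COc1ccc(C(=O)/C=C/c2cc(-c3cc(OC)c(OC)c(OC)c3)n[nH]2)cc1` gives 2490 nM. For the measured compounds named here, compound 2 therefore stands at the lower of the two numbers, with the step of a 2.7-fold lower number from compound 1 to compound 2 (0.43 log units; beyond the scatter) being the only measured step so far.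

Compound 3 `COc1cc(-c2cc(/C=C/C(=O)c3ccc(F)c(F)c3)[nH]n2)cc(OC)c1OC` differs from compound 2 by 3,4-difluorophenyl in place of 4-methoxyphenyl on a carbonyl carbon. Going by the values given here, the one step that bears on this change is a 2.7-fold lower number from compound 1 to compound 2 (0.43 log units; beyond the scatter), which ran from a dihalogenated ring to the methoxy ring and lowered the number beyond the scatter. Compound 3 returns to a dihalogenated ring of the same substitution pattern, so a step back upward is expected, roughly reversing that earlier step, though the two halogens differ.

Compound 3 is estimated to reach 5000 nM in this assay, within the range 2000 nM to 12000 nM, a step of a 2.0-fold higher number from compound 2 to compound 3 (0.30 log units; within the scatter) from compound 2 expected.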

Compound 3, concentration for total growth inhibition: 6010 nM
Compound 3: middle estimate off by 1.2-fold (0.08 log units), on the low side; low and high end bracket the measured number.
By their numbers in this assay, from the lowest: compound 2; then compounds 3 and 1 (each within the scatter of the next).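

On the carbonyl carbon, 3,4-difluorophenyl in place of 4-methoxyphenyl gives a 2.4-fold higher number from compound 2 to compound 3 (0.38 log units; beyond the scatter) in this assay, so a second dihalogenated ring now stands apart from the 4-methoxyphenyl group of compound 2, which holds the lowest number of the three. The exchange of 3,4-dichlorophenyl for 3,4-difluorophenyl gives a 1.1-fold lower number from compound 1 to compound 3 (0.05 log units; within the scatter), so the two dihalogenated rings cannot be told apart at this position. Nothing measured here accounts for these differences.

As far as these compounds go, it remains open whether the lower number of compound 2 belongs to the methoxy group itself or simply to a ring without halogens, a question that a plain phenyl or a 4-hydroxyphenyl on the carbonyl carbon could address. With a single halogen-free ring in hand, it is also unclear how far a 4-dimethylaminophenyl group would carry the number in either direction.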